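This account rests on a few compounds, and the source may have more. Where it says the series, first, only, none or still open, it means among the compounds named here.

Measured in a physicochemical assay for lipophilicity, at pH 7.4 (on this read-out higher numbers stand for higher lipophilicity and lower numbers for lower lipophilicity), compound 1 `CC(C)CN(c1cccc(F)c1)S(=O)(=O)c1ccc2c(c1)C(=O)CC(C1CCOCC1)O2` gives 3.5 and so sits within the scatter of compound 3 `CCc1ccc2c(c1)CC(C)CN2S(=O)(=O)c1ccc2c(c1)C(=O)CC(C1CCOCC1)O2` at 3.77 on this scale. Compound 2 `CCc1ccc(N(CC(C)C)S(=O)(=O)c2ccc(OCC3CCOCC3)c3c2CCC3=O)cc1` gives 4.44 on the same scale. Its number is higher than that of compound 1, by a gap larger than the scatter. The still unmeasured compound 4 `CC(C)CN(c1ccc(N(C)C)cc1)S(=O)(=O)c1ccc2c(c1)C(=O)CC(C1CCOCC1)O2` carries 4-(dimethylamino)phenyl in place of 3-fluorophenyl on a sulfonamide nitrogen and otherwise matches compound 1. For the measured compounds named here, no two measured compounds differ in one place only, so no measured step sizes this swap directly. The expected outcome is no clear shift in either direction. The estimated change is a number 0.10 log units higher from compound 1 to compound 4 (within the scatter) in this assay and stays within the scatter. For compound 4 the expected value is 3.6 with an estimated range from 3.1 to 4.1 on this scale.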

Compound 4, distribution coefficient: 3.6
The estimate for compound 4 equals the measured number at the digits printed, within the range that was stated.
By their numbers in this assay, from the lowest: compounds 1, 4 and 3 (each within the scatter of the next); then compound 2.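

For the compounds shown here, this is the first comparison in the set that differs in one place only: on a sulfonamide nitrogen, 4-(dimethylamino)phenyl in place of 3-fluorophenyl gives a number 0.10 log units higher from compound 1 to compound 4 (within the scatter) in this assay. The entering group has more heavy atoms and a hydrogen-bond acceptor that the leaving group lacks, yet the read-out shows no clear shift. Nothing measured here accounts for this outcome. Still open, on these data alone, is whether a phenyl ring bearing a carboxylic acid, or a saturated alkyl chain in place of the ring, would move the number on this sulfonamide nitrogen.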